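The source may hold more compounds than are shown below. What is called first, only, known or untested is meant among the compounds shown, and "the series" means these compounds.

Of the compounds shown here, three have been measured in an assay for inhibition of histone deacetylase 4 (Homo sapiens); on this read-out higher numbers stand for weaker inhibition and lower numbers for stronger inhibition. Compound 1 `O=C(NCc1ccccc1)c1ccc(C(=O)C(F)(F)F)s1` gives 243 nM, compound 3 `O=C(c1ccc(-c2nnc(-c3ccccc3)o2)s1)C(F)(F)F` gives 420 nM, and compound 2 `O=C(c1ccc(-c2nc(Cc3cccs3)no2)s1)C(F)(F)F` gives 15 nM. Compound 2 therefore stands lowest of the three, with its gap to compound 1 and its gap to compound 3 both beyond the usual scatter, so it is the strongest inhibitor shown. Compound 4 `O=C(c1ccc(-c2nc(-c3ccc(F)cc3F)no2)s1)C(F)(F)F` is not yet measured; it differs from compound 2 by one change, (2,4-difluorophenyl in place of (thiophen-2-yl)methyl on an aromatic carbon). Going by the values given here, no measured pair shows exactly this exchange, so the step is uncertain. A modest move toward weaker inhibition is expected, a 2.7-fold higher number from compound 2 to compound 4 (0.43 log units; beyond the scatter), with the estimate for compound 4 being 40 nM and a range from 10 nM to 160 nM.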

Compound 4, half-maximal inhibitory concentration: 120 nM
Beside the measured number, compound 4's estimate is 3.0-fold (0.48 log units) below it; the range from low to high includes it.
By their numbers in this assay, from the lowest: compound 2; then compound 4; then compounds 1 and 3 (each within the scatter of the next).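

In this assay, putting 2,4-difluorophenyl in place of (thiophen-2-yl)methyl gives an 8.0-fold higher number from compound 2 to compound 4 (0.90 log units; beyond the scatter), so the group on this aromatic carbon clearly affects inhibition. The exchange alters the ring and removes the methyl link in one move, so this single step cannot show which part matters. Nothing measured here explains the loss of inhibition. From the compounds shown here alone, it remains open whether a plain benzyl group, which keeps the link but carries a six-membered ring, would stay close to compound 2. An unsubstituted phenyl group would test the two fluorines.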